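This account rests on a few compounds, and the source may have more. Where it says the series, first, only, none or still open, it means among the compounds named here.

Compound 3 `Nc1nc(N2CCCC2)sc1C(=O)/C=C/c1ccc(Br)cc1` gives 41.3 ug/mL in a functional assay on MCF7 cells (Homo sapiens) for antiproliferative activity, read by MTT assay, with a stated time of 48 h; on this read-out higher numbers stand for weaker inhibition and lower numbers for stronger inhibition. Compound 2 `Nc1nc(N2CCCC2)sc1C(=O)/C=C/c1ccc(Cl)cc1` gives 24 ug/mL and compound 1 `Nc1nc(N2CCCC2)sc1C(=O)/C=C/c1ccccc1` gives 21.7 ug/mL in this assay, and the steps from both to compound 3 lie within the scatter. Compound 4 `Nc1nc(N2CCCC2)sc1C(=O)/C=C/c1ccc([N+](=O)[O-])cc1` carries the change (nitro in place of bromo on an aromatic carbon). For the measured compounds named here, the steps that bear on this position are a 1.9-fold higher number from compound 1 to compound 3 (0.28 log units; within the scatter) and a 1.7-fold higher number from compound 2 to compound 3 (0.24 log units; within the scatter), both within the scatter, as is a 1.1-fold higher number from compound 1 to compound 2 (0.04 log units; within the scatter). No substituent at this place has so far moved the number beyond the scatter, and no nitro group appears among the measured compounds. For compound 4 the step of a 1.3-fold lower number from compound 3 to compound 4 (0.11 log units; within the scatter) is therefore expected to stay within the scatter. For compound 4 the estimate is 32 ug/mL, with a range from 12 ug/mL to 85 ug/mL.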

Compound 4, half-maximal inhibitory concentration: 26.3 ug/mL
Beside the measured number, compound 4's estimate is 1.2-fold (0.09 log units) above it, within the range that was stated.
By their numbers in this assay, from the lowest: compounds 1, 2, 4 and 3 (each within the scatter of the next).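

Nitro joins hydrogen, chloro and bromo at this place without leaving the scatter, with a 1.6-fold lower number from compound 3 to compound 4 (0.20 log units; within the scatter) and a 1.1-fold higher number from compound 2 to compound 4 (0.04 log units; within the scatter) and also a 1.2-fold higher number from compound 1 to compound 4 (0.08 log units; within the scatter). Putting a group with hydrogen-bond acceptors in place of a halogen therefore gives no step beyond the scatter, and the four compounds remain unresolved on this read-out. No measurement is available that bears on the reason for this result. Going by these compounds, whether an amine or a carboxylic acid at this place would give a step beyond the scatter stays open, as do changes elsewhere on the shared core.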